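Chloro for trifluoromethyl: expected solubility of compound 4

This account rests on a few compounds, and the source may have more. Where it says the series, first, only, none or still open, it means among the compounds named here.

Three analogues that share one core have been measured in a physicochemical assay for solubility; on this read-out higher numbers stand for higher solubility and lower numbers for lower solubility. Compound 1 `COc1ccccc1C(=O)NC(=O)Nc1ccc(OCC(F)(F)F)c(C(F)(F)F)c1` gives < 1 ug/mL, which is a limit of the assay rather than a number. Compound 3 `COc1ccccc1C(=O)NC(=O)Nc1ccc(C(C)C)c(C(F)(F)F)c1` likewise gives < 1 ug/mL, again a limit. Among the measured compounds shown here, compound 2 `COc1ccccc1C(=O)NC(=O)Nc1ccc(N2CCCCC2)c(C(F)(F)F)c1` is the only one that returns a number, at 3 ug/mL. The step of an at least 3.0-fold higher number from compound 1 to compound 2 (0.47 log units; beyond the scatter) and the step of an at least 3.0-fold lower number from compound 2 to compound 3 (0.47 log units; beyond the scatter) both exceed the scatter, whereas a step that the two limits leave unreadable from compound 1 to compound 3 cannot be read because both ends sit at the limit of < 1 ug/mL in this assay, at which 2 of the 3 values shown sit. For the measured compounds named here, compound 2 therefore stands alone with the single measured value, while compounds 1 and 3 rest at the limit.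

Compound 4 `COc1ccccc1C(=O)NC(=O)Nc1ccc(N2CCCCC2)c(Cl)c1` keeps the piperidin-1-yl group of compound 2 and differs only by chloro in place of trifluoromethyl on an aromatic carbon. Going by the values given here, none of the measured steps alters this position; each of them exchanged the 2,2,2-trifluoroethoxy, piperidin-1-yl or isopropyl group, so they give no direct guide to the size of this change in this assay. Among the compounds with values here, with no measured step at that site, the change from trifluoromethyl to chloro is expected to stay within the scatter, or at most to be modest, with the direction not fixed by the data. Compound 4 is therefore estimated at 4 ug/mL, with a range from 1.5 ug/mL to 12 ug/mL. The step this estimate implies is expected to be a 1.3-fold higher number from compound 2 to compound 4 (0.12 log units; within the scatter).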

Compound 4, solubility: 3.6 ug/mL
Compound 4: middle estimate off by 1.1-fold (0.05 log units), on the high side; the range from low to high includes it.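

The only step shown at the position that carries trifluoromethyl is a 1.2-fold higher number from compound 2 to compound 4 (0.08 log units; within the scatter) and so, in this assay, compound 2 and compound 4 cannot be told apart. The earlier readable steps, an at least 3.0-fold higher number from compound 1 to compound 2 (0.47 log units; beyond the scatter) and an at least 3.0-fold lower number from compound 2 to compound 3 (0.47 log units; beyond the scatter) both lie beyond the scatter, but they exchanged the group at the other site and said nothing about this one. With the piperidin-1-yl group held in place, chloro with its 1 heavy atom can therefore stand in for trifluoromethyl with its 4 heavy atoms, ortho to that group, without a readable difference on this read-out, though that rests on this single pair.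

Going by these compounds, how a nitrile or a methyl group would read at this position, or whether an amine or a carboxylic acid at the piperidin-1-yl site would go beyond the values shown, remains open. Whether chloro would behave the same way alongside 2,2,2-trifluoroethoxy or isopropyl is also open, and the steps between the compounds that sit at the limit cannot be read: the limit of < 1 ug/mL in this assay, at which 2 of the 4 values shown sit.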